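Microsomal clearance notes, compounds 3 and 4

The source may report more compounds than this note shows. Statements on the series, on what has been measured and on what is new or still open speak of the compounds shown alone.

Measured so far:
- compound 1, `COc1ccccc1C(=O)Nc1[nH]nc(-c2ccccn2)c1C1CC1`: in an ADME assay on liver (Mesocricetus auratus) for metabolic stability, using microsomes (a higher number here means faster removal of the compound, a lower number slower removal), compound 1 gives > 100 mL.min-1.g-1, which is a limit of the assay and not a number.
- compound 2, `O=C(NCc1ccccc1)Nc1[nH]nc(-c2ccccn2)c1Cl`: in this assay compound 2 gives > 400 mL.min-1.g-1, again a limit of the assay.
- compound 3, `O=C(Nc1cc(-c2ccccn2)n[nH]1)N1CCC(Oc2ccccn2)CC1`: in this assay compound 3 gives 67.3 mL.min-1.g-1.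

Within the data shown here, compound 3 therefore stands as the only compound of the three with a measured number; the values of compound 1 and compound 2 are limits (the limit of > 100 mL.min-1.g-1 in this assay, at which 1 of the 3 values shown sits, and (the limit of > 400 mL.min-1.g-1 in this assay, at which 1 of the 3 values shown sits)), so no ordering among the three can be drawn from them.

Compound 4, `N#Cc1ccc(OC2CCN(C(=O)Nc3cc(-c4ccccn4)n[nH]3)CC2)cc1`, is not yet measured. It differs from compound 3 in one place: 4-cyanophenyl in place of pyridin-2-yl on an oxygen on a saturated carbon. Among the measured compounds shown here, no pair of measured compounds differs in a comparable single place, so the size of this step has no precedent here.

The change is expected to move the clearance little: the step from compound 3 to compound 4 in this assay is estimated at a 1.3-fold higher number from compound 3 to compound 4 (0.13 log units; within the scatter), upward but not clearly beyond the usual scatter. Compound 4 is accordingly expected to give about 90 mL.min-1.g-1, with a likely range from 40 mL.min-1.g-1 to 200 mL.min-1.g-1.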

Compound 4, intrinsic clearance in microsomes: 30.8 mL.min-1.g-1
For compound 4 the middle estimate is 2.9-fold (0.47 log units) above the measured one, and the stated range ends above it.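

Among these compounds, replacing pyridin-2-yl with 4-cyanophenyl on an oxygen on a saturated carbon gives a 2.2-fold lower number from compound 3 to compound 4 (0.34 log units; beyond the scatter) in this assay and is the first readable step, since the earlier compounds offered no pair differing in one place. It shows that the number in this assay responds to the aromatic group at this position, with the carbon-only ring bearing a nitrile giving slower removal than the ring with one hetero atom in this single pair. No measurement shown bears on the origin of this step, and the results for compound 1 and compound 2, both limits of the assay, add nothing to its reading.

Among the compounds shown here, the single step cannot separate the nitrile from the change of ring, a question that plain phenyl on the same oxygen would address directly. Also open, on these data alone, are whether an amine or a carboxylic acid in place of the nitrile would move the number in either direction, and whether the same step would hold on the cores of compound 1 and compound 2.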